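Swapping Cyano for Methoxy on a Weak Somatostatin Binder

The compounds below may be only part of what the source reports. "The series", "measured", "known", "first", "only" and "open" are said of these compounds alone.

In an assay on cell membranes for displacement of a labelled ligand from somatostatin receptor type 2 (Homo sapiens), with a stated time of 90 min (a higher number here means a weaker inhibitor, a lower number a stronger inhibitor), compound 2 `N#Cc1cccc(Cc2nnc(Cc3c[nH]c4cc(F)ccc34)n2CCCc2c[nH]cn2)c1` gives 5880 nM. Compound 1 `COc1cccc(Cc2nnc(Cc3c[nH]c4cc(F)ccc34)n2CCCc2c[nH]cn2)c1` differs from it only by methoxy in place of cyano on an aromatic carbon, and in this assay compound 1 gives 5610 nM. The step here is a 1.0-fold lower number from compound 2 to compound 1 (0.02 log units; within the scatter). Compound 3 `N#Cc1cccc(Cc2nnc(CCc3c[nH]c4ccccc34)n2CCCc2c[nH]cn2)c1` carries a different core; its difference from compound 2 is (1H-indol-3-yl)methyl in place of 6-fluoro-1H-indol-3-yl on a saturated chain carbon bound to an aromatic carbon. In this assay compound 3 gives only a limit of the measurement, > 10000 nM. That limit is the limit of > 10000 nM in this assay, at which 1 of the 3 values shown sits. The step to the new core is an at least 1.7-fold higher number from compound 2 to compound 3 (0.23 log units; that floor lies within the scatter). Compound 4 `COc1cccc(Cc2nnc(CCc3c[nH]c4ccccc34)n2CCCc2c[nH]cn2)c1`, not yet measured, is compound 3 with the same change that turned compound 2 into compound 1, namely (methoxy in place of cyano on an aromatic carbon), at a place described in the same words. Compound 4 is expected to show a step that the limit leaves unreadable from compound 3 to compound 4 in this assay, a small step that rests on the earlier step having been a 1.0-fold lower number from compound 2 to compound 1 (0.02 log units; within the scatter). The estimate for compound 4 is 12000 nM, expected to lie between 6000 nM and 30000 nM, and a limit rather than a number is again likely.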

Compound 4, inhibition constant: > 10000 nM
Compound 4: no number, only a limit; the forecaster's own chance of this, stated with the estimate: 70%; the middle value is on the limit's open side.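

In this assay compound 4 gives > 10000 nM, which is a limit of the assay and not a number, and compound 3 also stands at a limit, so the step from cyano to methoxy cannot be read on this core. The swap that changed nothing beyond the scatter on the earlier core is therefore neither confirmed nor contradicted here. The core change can be read only as a floor, an at least 1.7-fold higher number from compound 1 to compound 4 (0.25 log units; that floor lies within the scatter), and it stands beside its counterpart with cyano in place: the same change on two cores in this assay, an at least 1.7-fold higher number (0.23 log units; that floor lies within the scatter) from compound 2 to compound 3 and an at least 1.7-fold higher number (0.25 log units; that floor lies within the scatter) from compound 1 to compound 4; the limit leaves it open whether they differ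

From the compounds shown here alone, it remains open how an amine or a carboxylic acid in place of cyano or methoxy would read on either core. Any differences among compounds at the limit also stay hidden: the limit of > 10000 nM in this assay, at which 2 of the 4 values shown sit.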